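Replacing the Amine Group on the Shared Core

This account rests on a few compounds, and the source may have more. Where it says the series, first, only, none or still open, it means among the compounds named here.

Of the compounds shown here, three have been tested in an assay on HEK293 cells for inhibition of Fatty-acid amide hydrolase 1 (Homo sapiens), read by fluorescence; on this read-out lower numbers stand for stronger inhibition and higher numbers for weaker inhibition. Compound 1 `NC(=O)c1cccc(-c2ccc3oc(NC4CCCCC4)nc3c2)c1` gives > 1000 nM, which is a limit of the assay rather than a number. Compound 2 `c1ccc(-c2ccc3oc(NC4CCCCC4)nc3c2)cc1` gives > 1000 nM in this assay, again a limit. The step that the two limits leave unreadable from compound 1 to compound 2 cannot be sized because the limit of > 1000 nM in this assay, at which 2 of the 3 values shown sit, hides any difference between them.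

Compound 3 `CN(c1ccccc1)c1nc2cc(-c3ccc4c(ccn4C)c3)ccc2o1` gives 68 nM in this assay. Going by the values given here, this is the only actual number among the three; the other two values are limits, so compound 3 stands alone as the reference point.

Compound 4 `Cn1ccc2cc(-c3ccc4oc(N5Cc6cccnc6C5)nc4c3)ccc21` has not yet been measured. It differs from compound 3 by a group of 9 heavy atoms (7 carbon, 2 nitrogen; one five-membered non-aromatic ring with 1 hetero atom, one six-membered aromatic ring with 1 hetero atom) in place of a group of 8 heavy atoms (7 carbon, 1 nitrogen; one six-membered aromatic ring of carbon only), on an aromatic carbon. Among the compounds with values here, the single measured step concerns a different part of the molecule and is unreadable, so no measured step bears on this change, and nothing in the data sets a direction for it. Without a comparable step, the expectation is that the change stays within the usual scatter.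

Compound 4 is therefore expected to give about 100 nM in this assay, with a range from 30 nM to 400 nM. The expected step is a 1.5-fold higher number from compound 3 to compound 4 (0.17 log units; within the scatter).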

Compound 4, half-maximal inhibitory concentration: 211 nM
Compound 4: middle estimate off by 2.1-fold (0.32 log units), on the low side; the range from low to high includes it.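

Going by these compounds alone, this result gives the first readable step at the position on the aromatic carbon next to the ring nitrogen and next to the ring oxygen. In this assay, replacing methyl(phenyl)amino with the group holding a five-membered non-aromatic ring and a six-membered aromatic ring with 1 hetero atom gives a 3.1-fold higher number from compound 3 to compound 4 (0.49 log units; beyond the scatter), a modest change that lies beyond the usual scatter, so this position can carry either group and still give a real number, but the two groups are not interchangeable. Nothing measured here accounts for the direction of this step.

On these data alone, with only these two groups compared directly at this position, it remains open how a simpler ring amine such as piperidine or morpholine, or an open-chain amine such as dimethylamino, would read on the same core. As far as these compounds go, the step between compound 1 and compound 2 cannot be read, so what the carbamoyl group does also stays unknown, as does whether it would matter on a core carrying the group of compound 3 or compound 4.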